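The source may hold more compounds than are shown below. What is called first, only, known or untested is meant among the compounds shown, and "the series" means these compounds.

Measured so far in a functional assay on V79 cells (Cricetulus griseus) for cytotoxicity, read by colony formation; a higher number here means a weaker inhibitor, a lower number a stronger inhibitor
- compound 1 `C=Cn1cc(C(=O)O)c(=O)c2cc(F)c(N3CCC(N)C3)c(F)c21` gives 310 ug/mL
- compound 2 `CCNCC1CCN(c2nc3c(cc2F)c(=O)c(C(=O)O)cn3C2CC2)C1` gives 160 ug/mL
- compound 3 `COc1c(N2CCC(C)(CN)C2)c(F)cc2c(=O)c(C(=O)O)cn(C3CC3)c12` gives 38 ug/mL

Compound 2 (160 ug/mL) lies within the scatter of compound 1 and has a clearly higher number than compound 3. Compound 4 `CNCC1(C)CCN(c2nc3c(cc2F)c(=O)c(C(=O)O)cn3C2CC2)C1` keeps the core of compound 2 and exchanges one group (3-methyl-3-((methylamino)methyl)pyrrolidin-1-yl in place of 3-((ethylamino)methyl)pyrrolidin-1-yl on an aromatic carbon). It has 3-methyl-3-((methylamino)methyl)pyrrolidin-1-yl in place of 3-((ethylamino)methyl)pyrrolidin-1-yl on an aromatic carbon, next to the ring nitrogen and ortho to a fluoro group.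

Among the measured compounds shown here, no two measured compounds differ in one place only, so the data give no direct size for this step in this assay and any expectation remains uncertain. For the measured compounds named here, the nearest guide is compound 3 (38 ug/mL), the only measured compound whose pyrrolidine also carries a methyl, although its core differs from that of compound 2. The estimated step of a 1.8-fold lower number from compound 2 to compound 4 (0.25 log units; within the scatter) is a modest one toward a lower number. For compound 4 the estimated value is 90 ug/mL within an expected range (30 ug/mL to 260 ug/mL).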

Compound 4, half-maximal inhibitory concentration: 58 ug/mL
Estimate against measurement, compound 4: 1.6-fold (0.19 log units) above; measured number inside the range.
By their numbers in this assay, from the lowest: compounds 3 and 4 (each within the scatter of the next); then compounds 2 and 1 (each within the scatter of the next).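

In this assay, among the compounds shown here, 3-methyl-3-((methylamino)methyl)pyrrolidin-1-yl in place of 3-((ethylamino)methyl)pyrrolidin-1-yl on the aromatic carbon gives a 2.8-fold lower number from compound 2 to compound 4 (0.44 log units; beyond the scatter), the first step that changes one place only. The two groups have the same heavy-atom, donor and acceptor counts, and at this position a rearrangement of the same atoms is enough to move the number beyond the scatter. Nothing at hand bears on the cause of this step.

The exchange adds a methyl on the pyrrolidine ring and shortens the ethyl on the amine to a methyl, and the compounds shown do not separate these two changes. From the compounds shown here alone, on this core, 3-((methylamino)methyl)pyrrolidin-1-yl and 3-methyl-3-((ethylamino)methyl)pyrrolidin-1-yl would be needed to assign the step, and it remains open how a piperazine would compare at this position.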